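Pyrrolidinyl for piperidinyl in a bridged diphenyl series: cytotoxicity

The source may report more compounds than this note shows. Statements on the series, on what has been measured and on what is new or still open speak of the compounds shown alone.

Measured so far in an ADME assay on L6 cells (Rattus norvegicus) for cytotoxicity; on this read-out higher numbers stand for weaker inhibition and lower numbers for stronger inhibition:
Compound 1, `c1ccc(C2CC3(N4CCCCC4)CC(NCN4CCCC4)C2C(c2ccccc2)C3)cc1`: 43000 nM
Compound 2, `c1ccc(C2CC3(N4CCCC4)CCN(CCCN4CCCCC4)C2C(c2ccccc2)C3)cc1`: 28700 nM
Compound 3, `c1ccc(C2CC3(N4CCCCC4)CCN(CCCN4CCCCC4)C2C(c2ccccc2)C3)cc1`: 138000 nM

Among the compounds with values here, the one matched pair is compound 3 against compound 2, which gives a 4.8-fold lower number from compound 3 to compound 2 (0.68 log units; beyond the scatter) for the change (pyrrolidin-1-yl in place of piperidin-1-yl on a saturated ring carbon). Compound 1 and compound 3 share the same kind of bridged core but the difference between the two cores is not broken down here; their values stand apart, compound 1 sitting between compound 2 and compound 3 in this assay.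

Compound 4, `c1ccc(C2CC3(N4CCCC4)CC(NCN4CCCC4)C2C(c2ccccc2)C3)cc1`, is not yet measured. It carries the change pyrrolidin-1-yl in place of piperidin-1-yl on a saturated ring carbon relative to compound 1. The surroundings of the place are not identical to those in the pair of compound 3 and compound 2 (a ((pyrrolidin-1-yl)methyl)amino group on a neighbouring ring atom rather than a second phenyl), so this is the same kind of change, not the same one.

Resting on the step of a 4.8-fold lower number from compound 3 to compound 2 (0.68 log units; beyond the scatter) and on compound 1 at 43000 nM, a step of about a 2.9-fold lower number from compound 1 to compound 4 (0.46 log units; beyond the scatter) is expected. Compound 4 is therefore estimated at 15000 nM, with a range of 5000 nM to 50000 nM.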

Compound 4, half-maximal inhibitory concentration: 30600 nM
Estimate against measurement, compound 4: 2.0-fold (0.31 log units) below; low and high end bracket the measured number.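

On the core of compound 1, pyrrolidin-1-yl in place of piperidin-1-yl gives a 1.4-fold lower number from compound 1 to compound 4 (0.15 log units; within the scatter) in this assay, so no real shift can be read from this pair. The size of the step therefore does not carry over unchanged from one core to the other, and the two matched pairs give clearly different results: the same change on two cores in this assay, a 4.8-fold lower number (0.68 log units; beyond the scatter) from compound 3 to compound 2 and a 1.4-fold lower number (0.15 log units; within the scatter) from compound 1 to compound 4, 3.4-fold (0.53 log units) apart, beyond the scatter of two such steps

Within the data shown here, this shows only that the step is not a fixed increment across these two cores; it does not show which structural feature of the cores accounts for the gap, and two pairs set no rule for the rest of the series.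

Open, from the compounds shown here alone, is whether other amines in this place, such as morpholin-4-yl or an open-chain dimethylamino group, would follow the step seen on either core. Also open, going by these compounds, is whether the ((pyrrolidin-1-yl)methyl)amino group alone governs the size of the step, which would take a pair differing only in that group.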